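Oxazole ketone series: amide in place of pyrimidine

The source may hold more compounds than are shown below. What is called first, only, known or untested is meant among the compounds shown, and "the series" means these compounds.

In an assay (Rattus norvegicus) for inhibition of Fatty-acid amide hydrolase 1 (Homo sapiens) (a higher number here means a weaker inhibitor, a lower number a stronger inhibitor), compound 1 `O=C(CCCCCCc1ccccc1)c1ncc(-c2ccc([N+](=O)[O-])cc2)o1` gives 50 nM, compound 2 `Cc1ccnc(-c2cnc(C(=O)CCCCCCc3ccccc3)o2)c1` gives 0.6 nM and compound 3 `O=C(CCCCCCc1ccccc1)c1ncc(-c2ccncn2)o1` gives 2.3 nM. Compound 3 thus stands second highest of the three: a 3.8-fold higher number from compound 2 to compound 3 (0.58 log units; beyond the scatter) separates it from its nearest neighbour, and a 22-fold lower number from compound 1 to compound 3 (1.34 log units; beyond the scatter) from its furthest. Compound 4 `CNC(=O)c1cnc(C(=O)CCCCCCc2ccccc2)o1` carries methylcarbamoyl in place of pyrimidin-4-yl on an aromatic carbon. The measured steps, an 83-fold lower number from compound 1 to compound 2 (1.92 log units; beyond the scatter) and a 22-fold lower number from compound 1 to compound 3 (1.34 log units; beyond the scatter), both swap one six-membered ring for another at this carbon; none removes the ring, so they bear only loosely on this change. A weakening is nonetheless expected. Compound 4 is expected to give 20 nM in this assay, within 4 nM to 100 nM. That estimate means an 8.7-fold higher number from compound 3 to compound 4 (0.94 log units; beyond the scatter), an expected modest step upward in the number.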

Compound 4, inhibition constant: 7 nM
Compound 4: the middle estimate sits 2.9-fold (0.46 log units) above what was measured; measured number inside the range.
By their numbers in this assay, from the lowest: compound 2; then compound 3; then compound 4; then compound 1.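

In this assay a ring at this carbon proves dispensable: methylcarbamoyl costs a 3.0-fold higher number from compound 3 to compound 4 (0.48 log units; beyond the scatter) and a 12-fold higher number from compound 2 to compound 4 (1.07 log units; beyond the scatter) yet still gives a 7.1-fold lower number from compound 1 to compound 4 (0.85 log units; beyond the scatter) in exchange for 4-nitrophenyl. Ring versus no ring therefore does not alone set the order, since the ringless compound 4 outranks compound 1 while trailing compound 2 and compound 3. No measurement at hand accounts for this order.

From the compounds shown here alone, whether the amide hydrogen or the methyl group matters stays open. A primary amide, a dimethylamide or a carboxylic acid at this carbon would separate those contributions.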